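This account rests on a few compounds, and the source may have more. Where it says the series, first, only, none or still open, it means among the compounds named here.

Compound 3 `O=C(Nc1ccc(Cl)cc1)C(=O)N1CCC(c2ccnc3ccc(F)cc23)CC1` gives the lowest number of the three measured in an assay on SK-OV-3 cells for inhibition of Indoleamine 2,3-dioxygenase 1 (Homo sapiens) (on this read-out lower numbers stand for stronger inhibition and higher numbers for weaker inhibition), at 15 nM. Compound 2 `O=C(Nc1ccc(Cl)cc1)C(=O)N1CCC(c2ccccc2)CC1` gives 90 nM, and compound 1 `O=C(Nc1ccc(F)c(Cl)c1)C(=O)N1CCC(c2ccccc2)CC1` gives 1800 nM. Compound 4 `N#Cc1ccc(NC(=O)C(=O)N2CCC(c3ccnc4ccc(F)cc34)CC2)cc1` differs from compound 3 by cyano in place of chloro on an aromatic carbon, within the (4-chlorophenyl)amino part. Going by the values given here, no measured pair covers an exchange of chloro for cyano. Among the compounds with values here, the one measured step, a 20-fold lower number from compound 1 to compound 2 (1.30 log units; beyond the scatter), shows only that the substitution of this ring can move this assay a long way, though in that case the pattern of substituents changed rather than one group for another. Within the data shown here, with no direct precedent, only a modest shift in this assay is expected: a 1.7-fold higher number from compound 3 to compound 4 (0.22 log units; within the scatter). For compound 4 the estimate is 25 nM, with a range from 6 nM to 100 nM.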

Compound 4, half-maximal inhibitory concentration: 36 nM
Beside the measured number, compound 4's estimate is 1.4-fold (0.16 log units) below it, and the stated range covers the measured number.
By their numbers in this assay, from the lowest: compound 3; then compound 4; then compound 2; then compound 1.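

In this assay, the exchange of chloro for cyano gives a 2.4-fold higher number from compound 3 to compound 4 (0.38 log units; beyond the scatter), so this place, para to a large group, accepts a cyano group at a modest cost. Unlike the earlier step, which changed the pattern of substituents, this one replaces a single group and shows no swing of similar size. Nothing available explains the difference between these two groups. Going by these compounds, whether a methoxy group or an amine here would stay close to compound 3 remains open, as does whether cyano would give a similar step on compound 2.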